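Removing the propyl chain: from compound 3 to compound 4

The source may report more compounds than this note shows. Statements on the series, on what has been measured and on what is new or still open speak of the compounds shown alone.

Measured so far:
- compound 1, `CCC[C@@H](C(=O)N[C@H](C#N)CC(N)=O)N(Cc1ccc(-c2cccc(F)c2F)cc1)S(C)(=O)=O`: 7750 nM
- compound 2, `CS(=O)(=O)N(CC(=O)N[C@H](C#N)CC(N)=O)Cc1ccc(-c2cccc(F)c2F)cc1`: > 10000 nM
- compound 3, `CCC[C@@H](C(=O)N[C@H](C#N)CC(N)=O)N(Cc1ccc(-c2cccc(F)c2)cc1)S(C)(=O)=O`: 4380 nM

Of the compounds shown here, three share one core and have been tested in an assay on isolated protein for inhibition of legumain (Homo sapiens), with stated times of 2 min and 60 min; on this read-out higher numbers stand for weaker inhibition and lower numbers for stronger inhibition. Compound 1 gives 7750 nM. Compound 2 gives > 10000 nM, which is a limit of this assay and not a number. Compound 3 gives 4380 nM. Compound 3 and compound 1 sit within the scatter of each other, as the step of a 1.8-fold lower number from compound 1 to compound 3 (0.25 log units; within the scatter) shows, so nothing sets them apart; the value of compound 2 stays a limit.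

Compound 4, `CS(=O)(=O)N(CC(=O)N[C@H](C#N)CC(N)=O)Cc1ccc(-c2cccc(F)c2)cc1`, differs from compound 3 in one place: hydrogen in place of propyl on a saturated chain carbon bound to a carbonyl carbon and a sulfonamide nitrogen. The same change has been made once before, from compound 1 to compound 2, where it gave an at least 1.2-fold higher number from compound 1 to compound 2 (0.11 log units; that floor lies within the scatter). Going by the values given here, that step ends at a limit (the limit of > 10000 nM in this assay, at which 1 of the 3 values shown sits), so its true size is not known, only that the number did not fall. On this one precedent, compound 4 is expected to give a number in this assay at or beyond that limit, the step of a 2.5-fold higher number from compound 3 to compound 4 (0.40 log units; beyond the scatter) being the estimate.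

Compound 4 is therefore estimated at 11000 nM, with a range from 5000 nM to 30000 nM.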

Compound 4, half-maximal inhibitory concentration: > 10000 nM
Compound 4 was reported as a limit; the forecaster's own chance of this, stated with the estimate: 65%; the middle value lies beyond the limit too.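

In this assay, going by these compounds alone, hydrogen in place of propyl on a saturated chain carbon bound to a carbonyl carbon and a sulfonamide nitrogen gives an at least 2.2-fold higher number from compound 3 to compound 4 (0.35 log units; beyond the scatter), so for the first time the floor of this change lies beyond the scatter, whereas the floor of the earlier step did not. The number did not fall on either core, but the two steps cannot be ranked by size: the same change on two cores in this assay, an at least 1.2-fold higher number (0.11 log units; that floor lies within the scatter) from compound 1 to compound 2 and an at least 2.2-fold higher number (0.35 log units; beyond the scatter) from compound 3 to compound 4; the limit leaves it open whether they differ Compound 4 gives > 10000 nM, which is a limit of this assay and not a number, and the step from compound 2 to compound 4, which swaps hydrogen for fluoro on an aromatic carbon, cannot be read: the limit of > 10000 nM in this assay, at which 2 of the 4 values shown sit.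

From the compounds shown here alone, the true size of the loss on removing propyl stays open, as does any effect of that fluoro once the propyl chain is gone. Also open, going by these compounds, is whether a longer chain, a carboxylic acid or an amine on that same saturated chain carbon would give a lower number than compound 3 does.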